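This account rests on a few compounds, and the source may have more. Where it says the series, first, only, none or still open, it means among the compounds named here.

Compound 1 `C=C(C(=O)c1ccc(OC)cc1)C(OC(C)=O)C(CC)CC` gives 38900 nM in a functional assay on MCF7 cells (Homo sapiens) for inhibition, read by XTT assay, with a stated time of 48 h; a higher number here means a weaker inhibitor, a lower number a stronger inhibitor.
Compound 2 `C=C(C(=O)c1ccc(OC)cc1)C(OC(C)=O)c1ccc([N+](=O)[O-])cc1` gives 6100 nM in this assay.
Compound 3 `C=C(C(=O)c1ccc(OC)cc1)C(OC(=O)c1ccccc1)C(CC)CC` gives 17900 nM in this assay.

Compound 3 stands second highest of these three numbers. Its nearest neighbour is compound 1, whose number is higher; furthest away is compound 2, whose number is lower. Among the compounds with values here, the only step so far between compounds that differ in a single place is a 2.2-fold lower number from compound 1 to compound 3 (0.34 log units; beyond the scatter); it concerns the group on the carbonyl carbon of the ester and says nothing directly about the change considered next.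

Compound 4 `C=C(C(=O)c1ccc(OC)cc1)C(OC(=O)c1ccccc1)c1ccc([N+](=O)[O-])cc1` differs from compound 3 by 4-nitrophenyl in place of pentan-3-yl on a saturated chain carbon bound to a double-bonded chain carbon and an oxygen next to a carbonyl group. The same swap separates compound 1 from compound 2, which share the acetyl ester: compound 1 gives 38900 nM while compound 2 gives 6100 nM, a clearly lower number. Within the data shown here, no step was computed for that pair, but the two values point toward a substantial lowering of the number when the nitrophenyl group replaces the pentan-3-yl group. If the benzoyl ester of compound 3 behaves like the acetyl ester of compound 1, compound 4 should follow suit. Compound 4 is therefore expected near 2800 nM, with a plausible range from 1000 nM to 8000 nM. The expected step is a 6.4-fold lower number from compound 3 to compound 4 (0.81 log units; beyond the scatter).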

Compound 4, half-maximal inhibitory concentration: 56100 nM
Compound 4: middle estimate off by 20-fold (1.30 log units), on the low side; the measured number lies above the stated range.
By their numbers in this assay, from the lowest: compound 2; then compound 3; then compounds 1 and 4 (each within the scatter of the next).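

The swap of pentan-3-yl for 4-nitrophenyl on this saturated chain carbon has no single effect in this assay: with the benzoyl ester it gives a 3.1-fold higher number from compound 3 to compound 4 (0.50 log units; beyond the scatter), whereas with the acetyl ester compound 1 gives 38900 nM and compound 2 gives 6100 nM, a lower number. The ester change, phenyl in place of methyl on a carbonyl carbon, can now also be read with 4-nitrophenyl present, and it gives a 9.2-fold higher number from compound 2 to compound 4 (0.96 log units; beyond the scatter). Among these four compounds, then, neither change can be treated as a fixed increment, since the direction of each one depends on the group present at the other place: the same change on two cores in this assay, a 2.2-fold lower number (0.34 log units; beyond the scatter) from compound 1 to compound 3 and a 9.2-fold higher number (0.96 log units; beyond the scatter) from compound 2 to compound 4, 20-fold (1.30 log units) apart, beyond the scatter of two such steps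

The compounds shown leave open whether a plain phenyl or a cyclohexyl group on the chain carbon would behave like 4-nitrophenyl or like pentan-3-yl, and whether a longer chain in place of the methyl on the carbonyl carbon would side with the acetyl or the benzoyl ester. They also cannot tell why the two changes combine in this way.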